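Compound 2 to compound 3: an aryl change

A few compounds are considered here, and "the series" means these few. Any claim that something is new, unique, unknown or untested is made for them only; others in the source may bear on it.

In an ADME assay on SH-SY5Y cells (Homo sapiens) for cytotoxicity, read by MTT assay, with a stated time of 72 h (on this read-out lower numbers stand for stronger inhibition and higher numbers for weaker inhibition), compound 1 `Cc1ccc(C(=O)N2CCN(CC(=O)N3CCN(CCCc4c[nH]c5ccc(F)cc45)CC3)CC2)cc1` gives 119000 nM and compound 2 `O=C(CN1CCN(C(=O)c2cccc(Cl)c2)CC1)N1CCN(CCCc2c[nH]c3ccc(F)cc23)CC1` gives 59800 nM. These two values lie within the scatter of each other, so compound 2 cannot be ranked against compound 1.

Compound 3 `O=C(CN1CCN(C(=O)c2ccccc2Br)CC1)N1CCN(CCCc2c[nH]c3ccc(F)cc23)CC1` differs from compound 2 by 2-bromophenyl in place of 3-chlorophenyl on a carbonyl carbon. Within the data shown here, the only measured step that bears on this, a 2.0-fold lower number from compound 1 to compound 2 (0.30 log units; within the scatter), placed 3-chlorophenyl on the same carbonyl carbon in place of 4-methylphenyl. Among the measured compounds shown here, no measured compound carries 2-bromophenyl, so the direction of any change remains open. In this assay, no step beyond the scatter is expected. The expected change is a 1.0-fold higher number from compound 2 to compound 3 (0.00 log units; within the scatter). For compound 3 the estimated value is 60000 nM, with an expected range of 28000 nM to 125000 nM.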

Compound 3, half-maximal inhibitory concentration: 79100 nM
Estimate against measurement, compound 3: 1.3-fold (0.12 log units) below; the measured number falls inside the stated range.
By their numbers in this assay, from the lowest: compounds 2, 3 and 1 (each within the scatter of the next).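

In this assay, a third aryl group on the carbonyl carbon, whose other neighbour is an amide-type nitrogen in a ring, still gives no readable step: the change to 2-bromophenyl gives a 1.3-fold higher number from compound 2 to compound 3 (0.12 log units; within the scatter) and, against 4-methylphenyl, a 1.5-fold lower number from compound 1 to compound 3 (0.18 log units; within the scatter). Compounds 1, 2 and 3 therefore cannot be ranked in this assay, and 4-methylphenyl, 3-chlorophenyl and 2-bromophenyl cannot be told apart at this place. No further measurement bears on this result.

As far as these compounds go, whether a cyclohexyl or pyridyl group at this place would give a step beyond the scatter remains open. Also open, from the compounds shown here alone, is whether these three aryl groups would stay indistinguishable if the 3-carbon chain on the shared core were replaced by a longer chain.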